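Trimming the Aryl Ether of a Cinnamic Hydroxamic Acid

The source may hold more compounds than are shown below. What is called first, only, known or untested is meant among the compounds shown, and "the series" means these compounds.

Compound 1 `O=C(/C=C/c1cccc(Oc2ccccc2)c1)NO` was tested in an ADME assay on Huh-7 cells (Homo sapiens) for cytotoxicity, read by MTT assay, with a stated time of 3 days (a lower number here means that less compound is tolerated, a higher number that more compound is tolerated), and gave 20000 nM. Compound 3 `O=C(/C=C/c1ccc(OCCc2ccccc2)cc1)NO` gave 16000 nM in this assay, a number that lies within the usual scatter of the value of compound 1, so the two are not separated. Compound 2 `O=C(/C=C/c1cccc(OCCOc2ccccc2)c1)NO` gave 6000 nM, a lower number than that of compound 1 by a margin beyond the scatter. Compound 4 `COc1cccc(/C=C/C(=O)NO)c1` has not yet been measured in this assay. Compared with compound 1, it carries methyl in place of phenyl on an oxygen on an aromatic ring. Going by the values given here, no measured pair isolates this change. Given the narrow spread among the three measured values, compound 4 is expected to show a step of a 1.3-fold higher number from compound 1 to compound 4 (0.10 log units; within the scatter) that stays within the scatter. Compound 4 is therefore estimated at 25000 nM, with a range from 10000 nM to 60000 nM.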

Compound 4, half-maximal cytotoxic concentration: 17000 nM
Compound 4: middle estimate off by 1.5-fold (0.17 log units), on the high side; measured number inside the range.
By their numbers in this assay, from the lowest: compound 2; then compounds 3, 4 and 1 (each within the scatter of the next).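

At this place, on an oxygen on an aromatic ring, this assay gives a 1.2-fold lower number from compound 1 to compound 4 (0.07 log units; within the scatter) for methyl in place of phenyl. This first single-place comparison shows that the number does not separate when the six-membered aromatic ring gives way to a single carbon, so that ring is not required to keep the value of compound 1 at this level. Nothing available explains this result. Still open, on these data alone, is whether an ethyl group, a longer chain or an amine at this oxygen would also stay within the scatter of compound 1.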